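The source may hold more compounds than are shown below. What is called first, only, known or untested is meant among the compounds shown, and "the series" means these compounds.

Measured so far:
compound 1 `CCc1cc(C(C)=O)c(O)cc1OCCCC(C)(C)C#N` — an assay on isolated protein for inhibition of leukotriene B4 receptor 1 (Homo sapiens), tested at 10 uM; a higher number here means more inhibition at the concentration tested (going by the name of the read-out), a lower number less inhibition: 85%
compound 2 `C=CCc1cc(C(C)=O)c(O)cc1OCCCCCC(=O)NO` — this assay: 85%

In this assay compound 1 gives 85% and compound 2 gives 85%; the two stand level at the digits shown, within the scatter, so no order can be set between them. Compound 2 carries a different chain from compound 1 yet returns the same number, which is all that pair shows. The step followed here runs from compound 1 to compound 3 `CCc1cc(C(C)=O)c(O)cc1OCCCCCCC(=O)N(C)C`, not yet measured. The change is 3-(dimethylcarbamoyl)propyl in place of 1-cyano-1-methylethyl on a saturated chain carbon, three bonds along the chain from an oxygen on an aromatic ring. Among the measured compounds shown here, with only two measured compounds, both at one level, the expectation for compound 3 in this assay is a step of no more than the scatter, in no clear direction. Compound 3 is estimated at 80%, with a range from 55% to 95%. This estimate means a number 5 percentage points lower from compound 1 to compound 3 (within the scatter), expected to sit within the scatter.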

Compound 3, a percentage reported as inhibition, at one concentration (the size of the read-out at that concentration, not a potency): 100%
Estimate against measurement, compound 3: 20 percentage points below; the whole stated range lies below it.
By their numbers in this assay, from the lowest: compounds 1 and 2 (each within the scatter of the next); then compound 3.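

In this assay, the position three bonds along the chain from an oxygen on an aromatic ring accepts a larger group with a gain: 3-(dimethylcarbamoyl)propyl in place of 1-cyano-1-methylethyl gives a number 15 percentage points higher from compound 1 to compound 3 (beyond the scatter) in this series. Among the compounds shown here, this is the first step here that can be given a direction, and it shows that the nitrile of compound 1 is not needed to reach this level at the tested concentration. The change alters chain length and end group together, so the step cannot be assigned to either, and no measurement here bears on why the number moves.

Open, on these data alone, is whether a carboxylic acid or a primary amide on the same chain would hold the level of compound 3. Also open, as far as these compounds go, is how a shorter chain ending in the dimethylcarbamoyl group would compare.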